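The compounds below may be only part of what the source reports. "The series", "measured", "known", "first", "only" and "open" are said of these compounds alone.

Series measured in a functional assay (aorta) with Oryctolagus cuniculus as the target; on this read-out higher numbers stand for weaker binding and lower numbers for tighter binding:
- compound 1 `COc1cc(C(=O)O)ccc1OCCCN1CCC(C(c2ccc(F)cc2)c2ccc(F)cc2)CC1`: 79.4 nM
- compound 2 `COc1cc(C#N)ccc1OCCCN1CCC(C(c2ccc(F)cc2)c2ccc(F)cc2)CC1`: 2 nM

Compound 2 holds the lower number of this pair. Next is compound 3 `CC(=O)c1ccc(OCCCN2CCC(C(c3ccc(F)cc3)c3ccc(F)cc3)CC2)cc1`, with 4-acetylphenyl in place of 4-cyano-2-methoxyphenyl on an oxygen on a saturated carbon. Among the compounds with values here, one measured step bears on this only in part: a 40-fold lower number from compound 1 to compound 2 (1.60 log units; beyond the scatter), a large change for cyano in place of carboxy on an aromatic carbon. Within the data shown here, no measured step covers an acetyl group or the loss of the methoxy. A modest rise in this assay is expected, estimated as a 3.0-fold higher number from compound 2 to compound 3 (0.48 log units; beyond the scatter). For compound 3 the expected value is 6 nM, with an estimated range of 1.5 nM to 25 nM.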

Compound 3, dissociation constant: 2.51 nM
For compound 3 the middle estimate is 2.4-fold (0.38 log units) above the measured one, and the stated range covers the measured number.
By their numbers in this assay, from the lowest: compounds 2 and 3 (each within the scatter of the next); then compound 1.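

In this assay, 4-acetylphenyl in place of 4-cyano-2-methoxyphenyl on the oxygen gives a 1.3-fold higher number from compound 2 to compound 3 (0.10 log units; within the scatter) and so shows that a low number here needs neither the nitrile nor the methoxy. Against the carboxy compound, 4-acetylphenyl in place of 4-carboxy-2-methoxyphenyl gives a 32-fold lower number from compound 1 to compound 3 (1.50 log units; beyond the scatter) and so shows that the large step is not specific to the nitrile.

Going by these compounds, the nitrile and the methoxy leave together, so their separate shares stay unresolved, and it remains open whether an amine or a primary amide in place of the acetyl group holds this level. Nothing on hand explains these steps.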